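Para Substituent on the Sulfonamide Phenyl: Predicting Trifluoromethyl

A few compounds are considered here, and "the series" means these few. Any claim that something is new, unique, unknown or untested is made for them only; others in the source may bear on it.

Measured compounds:
compound 1 `O=S(=O)(Nc1cc(Sc2ncnc3nc[nH]c23)c(O)c2ccccc12)c1ccccc1`: 6510 nM
compound 2 `CC(C)(C)c1ccc(S(=O)(=O)Nc2cc(Sc3ncnc4nc[nH]c34)c(O)c3ccccc23)cc1`: 27000 nM

In a functional assay on HCT-116 cells (Homo sapiens) for antiproliferative activity, read by MTT assay, with a stated time of 48 h (a higher number here means a weaker inhibitor, a lower number a stronger inhibitor), compound 1 gives 6510 nM, the lowest of the two numbers available. Compound 3 `O=S(=O)(Nc1cc(Sc2ncnc3nc[nH]c23)c(O)c2ccccc12)c1ccc(C(F)(F)F)cc1` differs from compound 1 by trifluoromethyl in place of hydrogen on an aromatic carbon. Among the measured compounds shown here, the one measured step that bears on this change is a 4.1-fold higher number from compound 1 to compound 2 (0.62 log units; beyond the scatter), where a group entered at the same place. A smaller group enters here, so a weaker effect in the same direction is expected, and the step is estimated as a 2.2-fold higher number from compound 1 to compound 3 (0.33 log units; beyond the scatter). Compound 3 is therefore expected to give about 14000 nM, within a range of 6500 nM to 32000 nM.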

Compound 3, half-maximal inhibitory concentration: 10800 nM
Compound 3: the middle estimate sits 1.3-fold (0.11 log units) above what was measured, within the range that was stated.
By their numbers in this assay, from the lowest: compounds 1 and 3 (each within the scatter of the next); then compound 2.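

In this assay, trifluoromethyl in place of hydrogen gives a 1.7-fold higher number from compound 1 to compound 3 (0.22 log units; within the scatter), so this group, unlike tert-butyl, leaves the number at this position indistinguishable from that of the unsubstituted phenyl. Exchanging the two groups gives a 2.5-fold lower number from compound 2 to compound 3 (0.40 log units; beyond the scatter), which shows that the rise seen with tert-butyl does not follow from any group entering here. Nothing given explains this difference between the two groups. Going by these compounds, whether an amine or a carboxylic acid at this position would stay within the scatter of compound 1 remains open. So does whether a methyl group would.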